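Halogen exchange on the 4-chlorophenyl group of compound 2

A few compounds are considered here, and "the series" means these few. Any claim that something is new, unique, unknown or untested is made for them only; others in the source may bear on it.

Two compounds have numbers in an assay on SK-BR-3 cells for inhibition of Aromatase (Homo sapiens); on this read-out higher numbers stand for weaker inhibition and lower numbers for stronger inhibition. Compound 1 `CC(C)c1ccc(COc2cc([N+](=O)[O-])ccc2NS(C)(=O)=O)cc1` gives 7450 nM. Compound 2 `CS(=O)(=O)Nc1ccc([N+](=O)[O-])cc1OCc1ccc(Cl)cc1` gives 290 nM. Among the compounds with values here, the single step between them, a 26-fold lower number from compound 1 to compound 2 (1.41 log units; beyond the scatter), is beyond the scatter, so compound 2 stands at the lowest number of the two, with compound 1 as its only neighbour.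

Compound 3 `CS(=O)(=O)Nc1ccc([N+](=O)[O-])cc1OCc1ccc(Br)cc1` differs from compound 2 by bromo in place of chloro on an aromatic carbon; cut one bond further out, 4-chlorophenyl becomes 4-bromophenyl. Within the data shown here, no measured step concerns an exchange of one halogen for another. Among the measured compounds shown here, the only step in hand, a 26-fold lower number from compound 1 to compound 2 (1.41 log units; beyond the scatter), swaps a wholly different group for chloro and gives no guide to a chloro-to-bromo change at the same place. With nothing to point either way, in this assay compound 3 is expected to show a 1.2-fold lower number from compound 2 to compound 3 (0.06 log units; within the scatter), a step not beyond the scatter. Compound 3 is therefore estimated at 250 nM, with a range from 90 nM to 700 nM.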

Compound 3, half-maximal inhibitory concentration: 5850 nM
Compound 3: middle estimate off by 23-fold (1.37 log units), on the low side; measured number above the stated range.
By their numbers in this assay, from the lowest: compound 2; then compounds 3 and 1 (each within the scatter of the next).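

In this assay this position, on an aromatic carbon para to a large group, separates even two halogens that each count as one heavy atom: the exchange gives a 20-fold higher number from compound 2 to compound 3 (1.30 log units; beyond the scatter), as large as the step seen earlier with isopropyl. With a 1.3-fold lower number from compound 1 to compound 3 (0.11 log units; within the scatter), bromo and isopropyl cannot be told apart here, although one is a single heavy atom and the other is not. Among the three compounds, the low number therefore belongs to compound 2 with chloro alone, and the number of heavy atoms in the group does not order the series.

On these data alone, whether fluoro, methyl or nitrile at this place would fall with chloro or with bromo stays open. No measurement in hand gives a reason for the steep chloro-to-bromo step.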